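A few compounds are considered here, and "the series" means these few. Any claim that something is new, unique, unknown or untested is made for them only; others in the source may bear on it.

Compound 1 `COc1cc2c(Oc3ccc(NC(=O)c4cc(-c5ccc(C)cc5)ccn4)cc3F)ccnc2cc1OCCCN1CCCC1` and compound 2 `COc1cc2c(Oc3ccc(NC(=O)c4cc(-c5ccc(F)cc5)ccn4)cc3F)ccnc2cc1OCCCN1CCCC1` share a core and differ only in one place, (fluoro in place of methyl on an aromatic carbon). In a functional assay on A549 cells (Homo sapiens) for cytotoxicity, read by MTT assay, with a stated time of 72 h (on this read-out higher numbers stand for weaker inhibition and lower numbers for stronger inhibition), compound 1 gives 1060 nM, and compound 2 gives 1800 nM; the step is a 1.7-fold higher number from compound 1 to compound 2 (0.23 log units; within the scatter). Compound 3 `COc1cc2c(Oc3ccc(NC(=O)c4nccc(-c5ccc(C)cc5)n4)cc3F)ccnc2cc1OCCCN1CCCC1` carries a different core, and how its core differs from that of compound 1 is not broken down here; in this assay compound 3 gives "not determined" (no result reported), so no number is reported for it. Compound 4 `COc1cc2c(Oc3ccc(NC(=O)c4nccc(-c5ccc(F)cc5)n4)cc3F)ccnc2cc1OCCCN1CCCC1` stands to compound 3 as compound 2 stands to compound 1: the change is fluoro in place of methyl on an aromatic carbon, the same change made on the other core. With no value for compound 3 to build on, the expectation for compound 4 rests on compound 2, which gives 1800 nM, and on a 1.7-fold higher number from compound 1 to compound 2 (0.23 log units; within the scatter) lying within the scatter. Compound 4 is therefore expected to give about 2000 nM in this assay, roughly between 500 nM and 8000 nM.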

Compound 4, half-maximal inhibitory concentration: 990 nM
Estimate against measurement, compound 4: 2.0-fold (0.31 log units) above; the range from low to high includes it.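

Within the data shown here, with no number for compound 3 in this assay, no step from compound 3 to compound 4 can be read. What the 4-methylphenyl to 4-fluorophenyl change does on this core stays open, and no evidence shown bears on the result for compound 4.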